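Chloro in place of fluoro in compound 4

A few compounds are considered here, and "the series" means these few. Any claim that something is new, unique, unknown or untested is made for them only; others in the source may bear on it.

Measured so far:
compound 1, `CN(C)C(=O)c1cc2cnc(Nc3ccc(N)cn3)nc2n1C1CCCC1`: 60.1%
compound 2, `CN(C)C(=O)c1cc2cnc(Nc3ccc(NC(=O)C4(C(=O)Nc5ccc(Cl)cc5)CC4)cc3)nc2n1C1CCCC1`: 52.2%
compound 3, `CN(C)C(=O)c1cc2cnc(Nc3ccc(NC(=O)C4(C(=O)Nc5cccc(F)c5)CC4)cc3)nc2n1C1CCCC1`: 64.2%

Of the compounds shown here, three have been tested in a functional assay on NCI-H1299 cells (Homo sapiens) for inhibition, read by CCK-8 assay, with a stated time of 72 h, tested at 1 uM; on this read-out higher numbers stand for more inhibition of growth at the one concentration tested and lower numbers for less inhibition of growth. Compound 3 gives the highest of the three numbers, but compound 1 lies within the scatter of it, so the two cannot be ranked; only compound 2 stands clearly lower, the step being a number 12 percentage points higher from compound 2 to compound 3 (beyond the scatter).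

Compound 4, `CN(C)C(=O)c1cc2cnc(Nc3ccc(NC(=O)C4(C(=O)Nc5cccc(Cl)c5)CC4)cc3)nc2n1C1CCCC1`, is not yet measured. It differs from compound 3 in one place: chloro in place of fluoro on an aromatic carbon. Among the measured compounds shown here, the single measured step that involves this ring, the one from compound 2 to compound 3, changes both the halogen and its place on the ring at once, so it does not isolate the halogen itself. The pair of compounds 1 and 3 does not touch this ring at all. For the measured compounds named here, no measured step therefore speaks directly to swapping chloro for fluoro at the same position.

With that, the expectation for compound 4 is a step of a number 2.2 percentage points lower from compound 3 to compound 4 (within the scatter), which is no change beyond the scatter. Compound 4 is estimated at 62%, with a range from 50% to 74%.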

Compound 4, percent growth inhibition at one concentration: 47.9%
The estimate for compound 4 lay 14.1 percentage points above the measured number; the whole stated range lies above it.
By their numbers in this assay, from the lowest: compounds 4, 2, 1 and 3 (each within the scatter of the next, the first and the last beyond it).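

In this assay, the step with chloro in place of fluoro on the aromatic carbon gives a number 16.3 percentage points lower from compound 3 to compound 4 (beyond the scatter), which separates the halogen from its place on the ring, something the step between compound 2 and compound 3 could not do because it changed both at once. With the halogen held as chloro, 3-chlorophenyl in place of 4-chlorophenyl gives a number 4.3 percentage points lower from compound 2 to compound 4 (within the scatter), so among these compounds the two chloro compounds cannot be told apart, and only compound 3, with its fluoro, stands clearly above them. The data at hand offer no explanation of why fluoro and chloro part here.

The compounds shown leave open how a methoxy group, a nitrile or bromo would read in place of the fluoro of compound 3, and so whether fluoro is unusual at this place or chloro alone is the exception. From the compounds shown here alone, all the readings come from a single concentration, so it also stays open whether the gap between compound 3 and compound 4 would hold across a full dose-response curve.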